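Chloro to Methoxy on the Shared Core

The compounds below may be only part of what the source reports. "The series", "measured", "known", "first", "only" and "open" are said of these compounds alone.

For the measured compounds named here, compound 3 `COc1ccc(S(=O)(=O)c2cnc3ccc(Cl)cc3c2N2CCC(C)CC2)cc1Cl` gives 46% in an assay on isolated protein for displacement of a labelled ligand from metabotropic glutamate receptor 5 (Homo sapiens), with a stated time of 60 min, tested at 1 uM (on this read-out higher numbers stand for more inhibition at the one concentration tested (going by the name of the read-out) and lower numbers for less inhibition), the second highest of the three numbers so far. Its nearest neighbour is compound 2 `COc1ccc(S(=O)(=O)c2cnc3ccc(OC)cc3c2N2CCC(C)CC2)cc1`, which gives 41% in this assay, a gap within the usual scatter; furthest from it is compound 1 `COc1ccc(S(=O)(=O)c2cnc3ccc(C)cc3c2N2CCC(C)CC2)cc1Cl`, which gives 93% in this assay. Going by the values given here, the one step already measured at this site, a number 47 percentage points lower from compound 1 to compound 3 (beyond the scatter), was large. Compound 4 `COc1ccc2ncc(S(=O)(=O)c3ccc(OC)c(Cl)c3)c(N3CCC(C)CC3)c2c1` differs from compound 3 by methoxy in place of chloro on an aromatic carbon. Compound 2 already carries a methoxy at this place on the shared core, though the two compounds also differ elsewhere, and its number sits close to that of compound 3. Compound 4 is therefore expected to move little, with an estimated step of a number 1 percentage points lower from compound 3 to compound 4 (within the scatter), inside the scatter. The estimate for compound 4 is 45%, between 25% and 65%.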

Compound 4, a percentage reported as inhibition, at one concentration (the size of the read-out at that concentration, not a potency): 21%
The estimate for compound 4 lay 24 percentage points above the measured number; measured number outside the range, below it.
By their numbers in this assay, from the lowest: compound 4; then compounds 2 and 3 (each within the scatter of the next); then compound 1.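

In this assay methoxy in place of chloro on this aromatic carbon is a real change, giving a number 25 percentage points lower from compound 3 to compound 4 (beyond the scatter) and, measured against methyl at the same place, a number 72 percentage points lower from compound 1 to compound 4 (beyond the scatter) so that methyl, chloro and methoxy here now stand in that order. With methoxy already on the shared core, chloro in place of hydrogen elsewhere on the molecule gives a number 20 percentage points lower from compound 2 to compound 4 (beyond the scatter) so the near match of compound 2 and compound 3 said little about this position alone. Nothing available here explains these steps. From the compounds shown here alone, whether an amine or an ethoxy group at this place would fall above or below methoxy remains open. So does whether this order of groups would hold without the chloro elsewhere on the molecule.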